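This account rests on a few compounds, and the source may have more. Where it says the series, first, only, none or still open, it means among the compounds named here.

Of the compounds shown here, two built on one shared core have been tested in a functional assay on MDA-MB-435 cells (Homo sapiens) for cytotoxicity, read by sulforhodamine B assay, with a stated time of 48 h, tested at 0.001 uM; a higher number here means a weaker effect of the compound at the concentration tested, a lower number a stronger effect. Compound 1, `Cc1cc(O)cc(-c2nn(CC#N)cc2-c2ccnc(-c3ccc(Oc4ccccc4)cc3)c2)c1`, gives 103% in this assay. Compound 2, `COc1cc(C)cc(-c2nn(CC#N)cc2-c2ccnc(-c3ccc(N(C)C)cc3)c2)c1`, gives 103% in this assay. Compound 2 thus stands level with compound 1 at the digits shown, compound 1 being its nearest measured neighbour, and the gap between them lies within the usual scatter. At the concentration used, neither compound shows a measurable loss of cell growth.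

The unmeasured compound 3, `Cc1cc(O)cc(-c2nn(CC#N)cc2-c2ccnc(-c3ccc(N(C)C)cc3)c2)c1`, differs from compound 2 in one place: hydrogen in place of methyl on an oxygen on an aromatic ring. Read one bond further out, methoxy becomes hydroxy, and 3-methoxy-5-methylphenyl becomes 3-hydroxy-5-methylphenyl. Compound 1 already carries this 3-hydroxy-5-methylphenyl group, paired with a different group on the other arm, and gives 103% in this assay. With both measured compounds level and no effect visible at this concentration, the expected step is a number 1 percentage points lower from compound 2 to compound 3 (within the scatter) in this assay, none beyond the scatter. Compound 3 is therefore estimated to give 102%, with a range from 90% to 114%.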

Compound 3, a percentage reported as activity, at one concentration (the size of the read-out at that concentration, not a potency): 99%
Estimate against measurement, compound 3: 3 percentage points above, and the stated range covers the measured number.
By their numbers in this assay, from the lowest: compounds 3, 1 and 2 (each within the scatter of the next).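

Replacing methyl with hydrogen on the oxygen, which turns methoxy into hydroxy, gives a number 4 percentage points lower from compound 2 to compound 3 (within the scatter) in this assay, so at this concentration the two groups cannot be told apart when dimethylamino sits on the other arm. Among these compounds, compound 3 also allows the first clean look at that other arm: with the 3-hydroxy-5-methylphenyl group held fixed, dimethylamino in place of phenoxy on an aromatic carbon gives a number 4 percentage points lower from compound 1 to compound 3 (within the scatter), again too small to separate from repeat-to-repeat variation. Nothing available explains why either change leaves the read-out so flat.

All three compounds were read at a single low concentration at which none shows a clear effect on cell growth, so these results cannot say whether the methoxy, hydroxy, phenoxy or dimethylamino groups would matter at a concentration where growth is reduced. The compounds shown also leave open what an ethyl group or a longer chain on that oxygen would do, or a carboxylic acid in place of dimethylamino on the other arm.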